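The source may report more compounds than this note shows. Statements on the series, on what has been measured and on what is new or still open speak of the compounds shown alone.

Measured so far:
- compound 1 `Cc1ccc(Nc2nc(Cl)nc3c2ncn3Cc2ccc(/C=C/C(=O)Nc3ccccc3N)cc2)cc1` gives 51.3% in a functional assay on NCI-H460 cells (Homo sapiens) for antiproliferative activity, read by CCK-8 assay, with a stated time of 72 h, tested at 8 uM; on this read-out higher numbers stand for a stronger effect at the one concentration tested and lower numbers for a weaker effect
- compound 2 `Nc1ccccc1NC(=O)/C=C/c1ccc(Cn2cnc3c(Nc4cccc(Cl)c4)nc(Cl)nc32)cc1` gives 29.4% in this assay

For the measured compounds named here, only two compounds have been measured in this assay, and compound 2 stands lowest of the two numbers. Going by the values given here, its nearest neighbour is compound 1, and the single measured step between them, a number 21.9 percentage points lower from compound 1 to compound 2 (beyond the scatter), is beyond the scatter and of modest size; it exchanged one aromatic ring for another aromatic ring on the same nitrogen.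

Compound 3 `Nc1ccccc1NC(=O)/C=C/c1ccc(Cn2cnc3c(NC4CCCCC4)nc(Cl)nc32)cc1` is the next compound to be measured. It differs from compound 2 in one place: cyclohexyl in place of 3-chlorophenyl on a nitrogen on an aromatic ring. Among the compounds with values here, the one measured step, a number 21.9 percentage points lower from compound 1 to compound 2 (beyond the scatter), bears on the same position, but it compared two aromatic rings, whereas here an aromatic ring is replaced by a non-aromatic one, so it gives only loose guidance on the size of the effect. For compound 3 the step of a number 3.6 percentage points higher from compound 2 to compound 3 (within the scatter) is expected to be small and may well lie within the scatter. The estimate for compound 3 in this assay is therefore 33%, with a range from 13% to 55%.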

Compound 3, a percentage reported as inhibition, at one concentration (the size of the read-out at that concentration, not a potency): 24.9%
Beside the measured number, compound 3's estimate is 8.1 percentage points above it; measured number inside the range.
By their numbers in this assay, from the lowest: compounds 3 and 2 (each within the scatter of the next); then compound 1.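

Replacing the aromatic 3-chlorophenyl with the non-aromatic cyclohexyl on this nitrogen makes no clear difference in this assay (a number 4.5 percentage points lower from compound 2 to compound 3 (within the scatter)), so in this pair, whether the ring is aromatic has no effect that can be told from the scatter. Compound 1 now stands apart from both other compounds, as shown by the earlier step (a number 21.9 percentage points lower from compound 1 to compound 2 (beyond the scatter)) and the new one (a number 26.4 percentage points lower from compound 1 to compound 3 (beyond the scatter)), so an aromatic ring on this nitrogen is not enough by itself to give the higher number: compound 2 has one too, yet it cannot be separated from compound 3. No measured evidence is available to explain why 4-methylphenyl stands apart here.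

These three compounds leave open whether the methyl group or the change of ring substituent as a whole sets compound 1 apart, and an unsubstituted phenyl ring or a 4-chlorophenyl group on the same nitrogen would help to separate the two. As far as these compounds go, it also remains open how an open chain such as ethyl or a ring carrying a hydroxyl group would behave at this position.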